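The source may report more compounds than this note shows. Statements on the series, on what has been measured and on what is new or still open speak of the compounds shown alone.

In a functional assay on HT-29 cells (Homo sapiens) for inhibition, read by MTT assay, with a stated time of 72 h (a higher number here means a weaker inhibitor, a lower number a stronger inhibitor), compound 1 `COc1cc2c(Oc3ccc(NC(=O)c4nn(-c5ccccc5)c(=O)cc4C)cc3F)ccnc2cc1OCCCN1CCCC1` gives 220 nM, compound 2 `COc1cc2c(Oc3ccc(NC(=O)c4nn(-c5ccccc5)c(=O)cc4C)cc3F)ccnc2cc1OCCCN1CCCCC1` gives 160 nM and compound 3 `Cc1cc(=O)n(-c2ccccc2)nc1C(=O)Nc1ccc(Oc2ccnc3cc(OCCCN4CCC(C)CC4)ccc23)c(F)c1` gives 300 nM. For the measured compounds named here, the one single-point step among the three, a 1.4-fold lower number from compound 1 to compound 2 (0.14 log units; within the scatter), stays inside the scatter, and compound 2 sits alongside compound 1 and compound 3 with no separation beyond it. Compound 4 `COc1cc2c(Oc3ccc(NC(=O)c4nn(-c5ccccc5)c(=O)cc4C)cc3F)ccnc2cc1OCCCN1CCN(C)CC1` differs from compound 2 by 4-methylpiperazin-1-yl in place of piperidin-1-yl on a saturated chain carbon, three bonds along the chain from an oxygen on an aromatic ring. Going by the values given here, no measured pair exchanges a ring in this way; the only comparison at this position, a 1.4-fold lower number from compound 1 to compound 2 (0.14 log units; within the scatter), was flat, so for this assay a step no larger than the scatter is expected, a 1.3-fold higher number from compound 2 to compound 4 (0.10 log units; within the scatter), with no direction favoured. Compound 4 is accordingly estimated at 200 nM, within a range of 80 nM to 500 nM.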

Compound 4, half-maximal inhibitory concentration: 270 nM
Estimate against measurement, compound 4: 1.4-fold (0.13 log units) below, within the range that was stated.
By their numbers in this assay, from the lowest: compounds 2, 1, 4 and 3 (each within the scatter of the next).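

In this assay, putting 4-methylpiperazin-1-yl in place of piperidin-1-yl gives a 1.7-fold higher number from compound 2 to compound 4 (0.23 log units; within the scatter) and putting it in place of pyrrolidin-1-yl gives a 1.2-fold higher number from compound 1 to compound 4 (0.09 log units; within the scatter). A second ring nitrogen at this position, on a saturated chain carbon three bonds along the chain from an oxygen on an aromatic ring, therefore leaves the number within the scatter of both earlier rings. No measured evidence bears on this result.

Still open, as far as these compounds go, is whether a morpholin-4-yl ring, an open-chain dimethylamino group or a carboxylic acid at the chain end would stay as flat. Also open, from the compounds shown here alone, is whether the same holds on a shorter ethyl chain.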